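Thiazolidinedione aryl ethers: moving the chlorine on the phenyl

The compounds below may be only part of what the source reports. "The series", "measured", "known", "first", "only" and "open" are said of these compounds alone.

Measured so far:
compound 1 `Cc1cccnc1Oc1ccc(CC2SC(=O)NC2=O)cc1` — 1090 nM
compound 2 `O=C1NC(=O)C(Cc2ccc(Oc3ccccc3Cl)cc2)S1` — 1190 nM
To be measured: compound 3 `O=C1NC(=O)C(Cc2ccc(Oc3ccc(Cl)cc3)cc2)S1`

In a functional assay for agonist activity at Free fatty acid receptor 1 (Homo sapiens), read by FLIPR, in the presence of a further agent that is not named here (on this read-out lower numbers stand for an effect already at smaller amounts and higher numbers for an effect only at larger amounts of compound), compound 1 gives 1090 nM and compound 2 gives 1190 nM. For the measured compounds named here, the only step measured, a 1.1-fold higher number from compound 1 to compound 2 (0.04 log units; within the scatter), lies within the scatter, so the two numbers cannot be put in order and neither compound can be called the more potent one.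

Compound 3 differs from compound 2 by 4-chlorophenyl in place of 2-chlorophenyl on an oxygen on an aromatic ring. Going by the values given here, no measured step bears on this change: the single step seen, a 1.1-fold higher number from compound 1 to compound 2 (0.04 log units; within the scatter), exchanges one whole aryl group for another and gives no guide to shifting a chlorine within the same phenyl ring. With the aryl swap itself having moved the number within the scatter, the working expectation for this assay is a step from compound 2 to compound 3 of no size beyond the scatter, in either direction, with a wide range to allow for the absence of any comparable data. Compound 3 is therefore expected to give 1200 nM in this assay, in a range from 400 nM to 3600 nM. The expected step is a 1.0-fold higher number from compound 2 to compound 3 (0.00 log units; within the scatter).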

Compound 3, half-maximal effective concentration: 240 nM
Compound 3: the middle estimate sits 5.0-fold (0.70 log units) above what was measured; measured number outside the range, below it.
By their numbers in this assay, from the lowest: compound 3; then compounds 1 and 2 (each within the scatter of the next).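

In this assay the place of the chlorine on the phenyl counts: a 5.0-fold lower number from compound 2 to compound 3 (0.70 log units; beyond the scatter) comes with 4-chlorophenyl in place of 2-chlorophenyl on the oxygen, the atoms being the same and only joined differently. The earlier aryl exchange separated nothing, whereas a 4.5-fold lower number from compound 1 to compound 3 (0.66 log units; beyond the scatter) now sets 4-chlorophenyl apart from the 3-methylpyridin-2-yl group as well, so the group on this oxygen can move the number beyond the scatter. No measurement at hand says why the 4-chlorophenyl group gives the lower number.

Left open is whether chlorine itself is needed where 4-chlorophenyl carries it, or whether a fluorine, a methyl or a methoxy group there would serve as well. Equally open, going by these compounds, is whether the gain holds with a carboxylic acid in place of the ring of the shared core.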